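The compounds below may be only part of what the source reports. "The series", "measured", "known", "first", "only" and "open" are said of these compounds alone.

Among the three compounds measured so far in a functional assay on THP-1 cells (Homo sapiens) for inhibition, read by sulforhodamine B assay, with a stated time of 48 h, tested at 50 uM (on this read-out higher numbers stand for more inhibition of growth at the one concentration tested and lower numbers for less inhibition of growth), compound 1 (`COc1cccc(/C=C/C(=O)/C=C/c2ccc(OCc3cn(CCCCCOc4cc(=O)oc5ccccc45)nn3)c(OC)c2)c1`) gives 37%, the lowest number. Compound 2 (`COc1cccc(/C=C/C(=O)/C=C/c2ccc(OCc3cn(CCOc4cc(=O)oc5ccccc45)nn3)c(OC)c2)c1`) gives 77% and compound 3 (`COc1cc(/C=C/C(=O)/C=C/c2ccco2)ccc1OCc1cn(CCOc2cc(=O)oc3ccccc23)nn1`) gives 78%, and both lie beyond the scatter from compound 1.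

Compound 4 (`COc1cc(/C=C/C(=O)/C=C/c2cc(OC)c(OC)c(OC)c2)ccc1OCc1cn(CCCCCOc2cc(=O)oc3ccccc23)nn1`) has 3,4,5-trimethoxyphenyl in place of the 3-methoxyphenyl of compound 1, on a double-bonded chain carbon bound to a double-bonded chain carbon: 3,4,5-trimethoxyphenyl in place of 3-methoxyphenyl on a double-bonded chain carbon bound to a double-bonded chain carbon.

Going by the values given here, only one measured step changes the group at this place, the swap of 3-methoxyphenyl for furan-2-yl: a number 1 percentage points higher from compound 2 to compound 3 (within the scatter). That swap left this assay within the scatter, which suggests that this place may matter little. Among the compounds with values here, it is only a weak guide, though, since it involves a different group on a different parent, and no compound with 3,4,5-trimethoxyphenyl has been measured yet.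

No shift beyond the scatter is therefore expected, and the expected step is a number 5 percentage points higher from compound 1 to compound 4 (within the scatter). For compound 4 the estimated value is 42%, with an expected range from 25% to 62%.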

Compound 4, percent growth inhibition at one concentration: 55%
Compound 4: the middle estimate sits 13 percentage points below what was measured; the measured number falls inside the stated range.
By their numbers in this assay, from the lowest: compound 1; then compound 4; then compounds 2 and 3 (each within the scatter of the next).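

In this assay the change to 3,4,5-trimethoxyphenyl gives a number 18 percentage points higher from compound 1 to compound 4 (beyond the scatter) and so shows that the group at this place can shift the number beyond the scatter, on the parent of compound 1 at least. The earlier swap to furan-2-yl gave only a number 1 percentage points higher from compound 2 to compound 3 (within the scatter) and could not show this, so the two steps together suggest that the effect depends on the group entering, the parent, or both. Nothing available here explains the rise in the number.

On these data alone, it remains open whether the same change to 3,4,5-trimethoxyphenyl would also shift the number on the parent of compound 2, which carries a shorter chain. As far as these compounds go, it is equally open how an amine or a carboxylic acid on the phenyl ring at this place would compare.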